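The source may report more compounds than this note shows. Statements on the series, on what has been measured and on what is new or still open speak of the compounds shown alone.

In a functional assay on MCF7 cells (Homo sapiens) for antiproliferative activity, read by MTT assay, with a stated time of 72 h (on this read-out lower numbers stand for stronger inhibition and higher numbers for weaker inhibition), compound 1 `CC/C=C/C(=O)Nc1cccc(Oc2nc(Nc3cccc(OC)c3)nc3c2CSCC3)c1` gives 24200 nM and compound 2 `CCC/C=C/C(=O)Nc1cccc(Oc2nc(Nc3cccc(OC)c3)nc3c2CSCC3)c1` gives 32000 nM, so these two lie within the scatter of each other. Compound 3 `C=C(F)C(=O)Nc1cccc(Oc2nc(Nc3cccc(OC)c3)nc3c2CSCC3)c1` reaches only a limit, > 50000 nM. Among the measured compounds shown here, compound 1 therefore stands level with compound 2, and it is the only other measured number.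

Compound 4 `CC/C=C/C(=O)Nc1cccc(Oc2nc(Nc3cccc(C#N)c3)nc3c2CSCC3)c1` keeps the but-1-en-1-yl group on the carbonyl carbon of compound 1 and changes the aromatic ring instead, from 3-methoxyphenyl to 3-cyanophenyl: cyano in place of methoxy on an aromatic carbon.

The measured steps all change the group on the carbonyl carbon: a 1.3-fold higher number from compound 1 to compound 2 (0.12 log units; within the scatter), an at least 2.0-fold higher number from compound 1 to compound 3 (0.31 log units; beyond the scatter) and an at least 1.5-fold higher number from compound 2 to compound 3 (0.19 log units; that floor lies within the scatter). None of them replaces the methoxy group, so they bear on this change only indirectly and give no direction for it. No shift beyond the scatter is expected in this assay, though the uncertainty is wide. The expected change is a 1.0-fold lower number from compound 1 to compound 4 (0.00 log units; within the scatter). For compound 4 the estimated value is 24000 nM, with an expected range of 9000 nM to 60000 nM.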

Compound 4, half-maximal inhibitory concentration: 15900 nM
Compound 4: middle estimate off by 1.5-fold (0.18 log units), on the high side; low and high end bracket the measured number.
By their numbers in this assay, from the lowest: compounds 4, 1 and 2 (each within the scatter of the next). At a limit, above all of these: compound 3.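

In this assay, the swap of 3-methoxyphenyl for 3-cyanophenyl gives a 1.5-fold lower number from compound 1 to compound 4 (0.18 log units; within the scatter). Among the compounds shown here, this is the first reading at this aromatic carbon, since compounds 1, 2 and 3 differ only in the group on the carbonyl carbon and all carry methoxy; it shows that cyano in place of methoxy, with but-1-en-1-yl held constant, produces no shift beyond the scatter. Nothing to hand explains this step, or says what the two groups do at this carbon.

Going by these compounds, it remains open whether an amine, a carboxylic acid or a longer alkoxy chain on this carbon would move the number beyond the scatter. On these data alone, it is also open whether cyano gives the same result alongside pent-1-en-1-yl or 1-fluoroethenyl on the carbonyl carbon.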